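The compounds below may be only part of what the source reports. "The series", "measured", "known", "first", "only" and "open" are said of these compounds alone.

Measured in a functional assay on the whole organism for inhibition, with Rattus norvegicus as the target, with a stated time of 2 h, at a dose of 100 mg/kg by the oral route; a higher number here means more inhibition at the dose given (going by the name of the read-out), a lower number less inhibition:
compound 1 `Cc1nnc(-c2nsc3ccccc23)o1`: 43%
compound 2 `c1ccc(-c2nnc(-c3nsc4ccccc34)o2)cc1`: 60%
compound 3 `Clc1ccc(-c2nnc(-c3nsc4ccccc34)o2)cc1`: 13%

Compound 3 stands lowest of the three; its nearest neighbour is compound 1, and compound 2 lies furthest from it. Compound 4 `COc1ccc(-c2nnc(-c3nsc4ccccc34)o2)cc1` is not yet measured; it differs from compound 3 in one place: methoxy in place of chloro on an aromatic carbon. Going by the values given here, no measured step swaps chloro for methoxy, so the known steps bear on it only indirectly. The closest is chloro in place of hydrogen, a number 47 percentage points lower from compound 2 to compound 3 (beyond the scatter), a large drop. The other two, a number 17 percentage points higher from compound 1 to compound 2 (beyond the scatter) and a number 30 percentage points lower from compound 1 to compound 3 (beyond the scatter), show the unsubstituted phenyl giving the higher reading and the chloro-bearing phenyl the lower one. Taking chloro away removes the group tied to the largest fall, but methoxy replaces it, and no compound shows how a methoxy on that ring behaves in this assay. The expectation is a step upward from compound 3, a number 22 percentage points higher from compound 3 to compound 4 (beyond the scatter), with wide uncertainty. Compound 4 is estimated at 35%, between 10% and 60%.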

Compound 4, a percentage reported as inhibition, in the whole organism at one dose (the size of the read-out at that dose, not a potency): 21%
Estimate against measurement, compound 4: 14 percentage points above; the range from low to high includes it.
By their numbers in this assay, from the lowest: compounds 3 and 4 (each within the scatter of the next); then compound 1; then compound 2.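

In this assay, methoxy in place of chloro on the aromatic carbon para to a large group gives a number 8 percentage points higher from compound 3 to compound 4 (within the scatter) and so leaves these two substituents unseparated at this position. Methoxy in place of hydrogen gives a number 39 percentage points lower from compound 2 to compound 4 (beyond the scatter) and chloro in place of hydrogen gives a number 47 percentage points lower from compound 2 to compound 3 (beyond the scatter) so the higher reading belongs to the unsubstituted phenyl of compound 2 and not to the phenyl ring as such, with neither substituted compound going against this among the four compounds shown. No measurement on hand accounts for this drop.

On these data alone, it remains open whether an amine, a hydroxy group or a carboxylic acid at this position would stay close to compound 2 or fall with compound 3 and compound 4. As far as these compounds go, it also remains open whether chloro or methoxy elsewhere on the phenyl ring would give the same drop.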